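One group exchanged on compound 2

The source may report more compounds than this note shows. Statements on the series, on what has been measured and on what is new or still open speak of the compounds shown alone.

Of the compounds shown here, two have so far been measured in an ADME assay on the whole organism (Mus musculus, strain CD1) for pharmacokinetics, with a stated time of 24 h, at a dose of 10 mg/kg by the oral route; on this read-out lower numbers stand for lower oral bioavailability and higher numbers for higher oral bioavailability. Compound 1 (`CN(C)c1noc(-c2cccc(CN(C)c3ccc4[nH]nc(C(=O)O)c4c3)c2O)n1`) gives 4%, and compound 2 (`CC(C)c1noc(-c2cccc(CNc3ccc4[nH]nc(C(=O)O)c4c3)c2O)n1`) gives 2%. Compound 2 therefore stands within the usual scatter of compound 1, and the two numbers cannot be told apart.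

Compound 3 (`Cc1nc(-c2cccc(CNc3ccc4[nH]nc(C(=O)O)c4c3)c2O)sc1C`) has not yet been measured. It carries 4,5-dimethyl-1,3-thiazol-2-yl in place of the 3-isopropyl-1,2,4-oxadiazol-5-yl of compound 2, on an aromatic carbon, ortho to a hydroxy group (4,5-dimethyl-1,3-thiazol-2-yl in place of 3-isopropyl-1,2,4-oxadiazol-5-yl on an aromatic carbon). The rest of the structure stays as it is in compound 2.

Among the measured compounds shown here, the measured pair offers no step in which only one place changes, so the data give no direct measure of such an exchange. Compound 1 and compound 2 differ in more than one place, yet their numbers stay within the scatter. No shift beyond the scatter is therefore expected in this assay, in either direction. The estimated step is a number 3 percentage points higher from compound 2 to compound 3 (within the scatter), and it is expected to remain small. For compound 3 the expected value is 5%, with an estimated range from 1% to 16%.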

Compound 3, oral bioavailability: 19%
Beside the measured number, compound 3's estimate is 14 percentage points below it, outside the stated range (above it).
By their numbers in this assay, from the lowest: compounds 2 and 1 (each within the scatter of the next); then compound 3.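

In this assay, putting 4,5-dimethyl-1,3-thiazol-2-yl in place of 3-isopropyl-1,2,4-oxadiazol-5-yl on the aromatic carbon ortho to a hydroxy group gives a number 17 percentage points higher from compound 2 to compound 3 (beyond the scatter). Among the compounds shown here, this is the first step that changes only one place, and it shows that the group on this carbon can move oral bioavailability in mice beyond the scatter, which the earlier pair, differing in more than one place, could not show. Nothing measured here accounts for the rise, so the result records the size of the change but not its origin.

The exchange alters the ring and its substituents together, so this one step cannot assign the rise to the 1,3-thiazole ring itself or to its two methyl groups, and an unsubstituted 1,3-thiazol-2-yl would be needed to separate them. Going by these compounds, it also remains open how other groups on this carbon, such as a 4-methyl-1,3-thiazol-2-yl or a simple phenyl ring, would read in this assay, and whether the same exchange would have a similar effect on compound 1.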